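Methoxy for methyl on compound 2

A few compounds are considered here, and "the series" means these few. Any claim that something is new, unique, unknown or untested is made for them only; others in the source may bear on it.

In a functional assay on B16-F10 cells (Mus musculus) for inhibition, read by colorimetric assay and MTT assay, with a stated time of 72 h (on this read-out lower numbers stand for stronger inhibition and higher numbers for weaker inhibition), compound 2 (`Cc1ccc(C(=O)NNC(=S)Nc2csc(-c3ccc(C)cc3)c2)cc1`) reads 20000 nM and lies within the scatter of compound 3 (`COc1cc(C(=O)NNC(=S)Nc2csc(-c3ccccc3)c2)cc(OC)c1OC`) at 32000 nM but clearly higher than compound 1 (`COc1ccc(-c2cc(NC(=S)NNC(=O)c3ccc(C)cc3)cs2)cc1`) at 7000 nM on this scale. Compound 4 (`COc1ccc(C(=O)NNC(=S)Nc2csc(-c3ccc(C)cc3)c2)cc1`) differs from compound 2 by a single change (methoxy in place of methyl on an aromatic carbon), methoxy in place of methyl on an aromatic carbon. Among the compounds with values here, the one measured step bearing on this is a 2.9-fold higher number from compound 1 to compound 2 (0.46 log units; beyond the scatter) for methyl in place of methoxy, though on a different aromatic ring. That makes it a loose guide, so a modest move toward stronger inhibition is expected. The estimated step is a 1.8-fold lower number from compound 2 to compound 4 (0.26 log units; within the scatter) on this reasoning. Compound 4 is estimated at 11000 nM with a range of 4000 nM to 30000 nM as the expected span.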

Compound 4, half-maximal inhibitory concentration: 9000 nM
Estimate against measurement, compound 4: 1.2-fold (0.09 log units) above; measured number inside the range.
By their numbers in this assay, from the lowest: compounds 1 and 4 (each within the scatter of the next); then compounds 2 and 3 (each within the scatter of the next).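

Swapping methyl for methoxy on this ring, para to a large group, gives a 2.2-fold lower number from compound 2 to compound 4 (0.35 log units; beyond the scatter) in this assay, so the swap counts here as well as on the other aromatic ring. The earlier step, a 2.9-fold higher number from compound 1 to compound 2 (0.46 log units; beyond the scatter), is the same swap on that other ring read in reverse, so in both places the methoxy compound has the lower number. No measurement shown here explains this shift.

Still open, on these data alone, is how an amine or a longer ethoxy chain would read at this carbon. Also open, as far as these compounds go, is whether methoxy on both rings would lower the number further.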